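Two Compounds at the Assay Limit, One to Come

A few compounds are considered here, and "the series" means these few. Any claim that something is new, unique, unknown or untested is made for them only; others in the source may bear on it.

Measured in an ADME assay on cells (Erythrocyte, Homo sapiens), read by spectrophotometry and hemolysis, with a stated time of 24 h; a higher number here means a weaker inhibitor, a lower number a stronger inhibitor:
- Compound 1 `NC(=O)N/N=C/c1ccc(OCc2ccc3no[n+]([O-])c3c2)cc1`: > 200 uM (a limit)
- Compound 2 `CC(=O)c1ccccc1OCc1ccc2no[n+]([O-])c2c1`: > 200 uM (a limit)

In this assay, compound 2 gives > 200 uM, which is a limit of the assay and not a number. Compound 3 `NC(=S)N/N=C\c1ccccc1OCc1ccc2no[n+]([O-])c2c1` has not yet been measured. It carries a group of 6 heavy atoms in place of the acetyl of compound 2, on an aromatic carbon (a group of 6 heavy atoms (2 carbon, 3 nitrogen, 1 sulfur; no ring) in place of a group of 3 heavy atoms (2 carbon, 1 oxygen; no ring), on an aromatic carbon). Going by the values given here, no measured step between compounds is available to gauge this change. Because of the limit of > 200 uM in this assay, at which 2 of the 2 values shown sit, no change beyond the usual scatter is expected, in either direction. The expected change is a number no higher from compound 2 to compound 3 (the limit leaves the size open). Compound 3 is estimated at 200 uM, with an expected range of 110 uM to 360 uM.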

Compound 3, concentration for 50% inhibition: 189 uM
Compound 3: middle estimate off by 1.1-fold (0.02 log units), on the high side; the measured number falls inside the stated range.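

With the group of compound 3 in place of the acetyl on this aromatic carbon, this assay yields a number rather than a limit: compound 3 gives 189 uM here. Compound 2 gives > 200 uM as a limit of the assay. The step reads an at least 1.0-fold lower number from compound 2 to compound 3 (0.02 log units; that floor lies within the scatter) and remains only a floor because of the following: the limit of > 200 uM in this assay, at which 2 of the 3 values shown sit.

From the compounds shown here alone, whether a simple amine or a carboxylic acid on this aromatic carbon would shift the number beyond the scatter stays open. Going by these compounds, the true size of the step also stays open.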